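Swapping 4-methylphenyl for 3-chlorophenyl on a shared core

This account rests on a few compounds, and the source may have more. Where it says the series, first, only, none or still open, it means among the compounds named here.

Of the compounds shown here, two have so far been measured in a functional assay on MCF7 cells (Homo sapiens) for cytotoxicity, read by ELISA, with a stated time of 4 days; a lower number here means a stronger inhibitor, a higher number a weaker inhibitor. Compound 1 (`Clc1cccc(-c2cc(-c3ccoc3)cc(-c3ccc(Cl)s3)n2)c1`) gives 2920 nM, and compound 2 (`Cc1ccc(-c2cc(-c3ccc(Cl)o3)cc(-c3ccc(Cl)s3)n2)cc1`) gives 3040 nM. Compound 2 thus stands level with compound 1, the two values lying within the usual scatter of each other. The next compound, compound 3 (`Clc1cccc(-c2cc(-c3ccc(Cl)o3)cc(-c3ccc(Cl)s3)n2)c1`), departs from compound 2 in one place: 3-chlorophenyl in place of 4-methylphenyl on an aromatic carbon. It carries 3-chlorophenyl in place of 4-methylphenyl on an aromatic carbon of a six-membered aromatic ring with 1 nitrogen, next to the ring nitrogen, meta to a 5-chlorofuran-2-yl group and meta to a 5-chlorothiophen-2-yl group. Among the compounds with values here, no measured pair differs in one place only, so the data offer no direct guide to this exchange. The only support is the closeness of compound 1 at 2920 nM to compound 2 at 3040 nM, and on that ground no step beyond the scatter is expected in this assay, in either direction. The estimated 1.1-fold lower number from compound 2 to compound 3 (0.04 log units; within the scatter) stays within the usual scatter. For compound 3 the expected value is 2800 nM, with an estimated range from 1200 nM to 6500 nM.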

Compound 3, half-maximal inhibitory concentration: 15100 nM
The estimate for compound 3 lay 5.4-fold (0.73 log units) below the measured number; the measured number lies above the stated range.
By their numbers in this assay, from the lowest: compounds 1 and 2 (each within the scatter of the next); then compound 3.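

In this assay, the aromatic carbon next to the ring nitrogen proves sensitive to the choice of aryl group: 3-chlorophenyl in place of 4-methylphenyl gives a 5.0-fold higher number from compound 2 to compound 3 (0.70 log units; beyond the scatter), even though both groups carry the same count of heavy atoms and neither has a hydrogen-bond donor or acceptor. Within the data shown here, the second place also matters, since 5-chlorofuran-2-yl in place of furan-3-yl gives a 5.2-fold higher number from compound 1 to compound 3 (0.71 log units; beyond the scatter), so each of these single exchanges moves the number beyond the scatter, which no earlier pair could show. Nothing available accounts for either step, and the size of the two steps alone gives no reason for them.

The compounds shown leave open whether the step at the first place follows the chlorine, the loss of the methyl or the different placing of the substituent, a question that 4-chlorophenyl or 3-methylphenyl would address. They also leave open how 4-methylphenyl behaves alongside furan-3-yl, and whether a phenyl ring bearing an amine or a carboxylic acid would be accepted at this carbon.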